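Peptide sulfonamide series: carbamoyl for isopropyl at the inner position

The source may report more compounds than this note shows. Statements on the series, on what has been measured and on what is new or still open speak of the compounds shown alone.

Compound 2 `CSCC[C@H](NC(=O)[C@H](CC(C)C)NC(=O)[C@H](CC(C)C)NC(=O)CC[C@H](NS(=O)(=O)c1ccc(Cl)c(C(F)(F)F)c1)C(=O)O)C(N)=O` stands lowest of the two numbers in an assay on isolated protein for inhibition of Matrilysin (Homo sapiens), read by fluorescence, with a stated time of 15 min; on this read-out lower numbers stand for stronger inhibition and higher numbers for weaker inhibition; compound 2 gives 780 nM. Compound 1 `CSCC[C@H](NC(=O)[C@H](CC(C)C)NC(=O)[C@H](CO)NC(=O)CC[C@H](NS(=O)(=O)c1ccc(Cl)c(C(F)(F)F)c1)C(=O)O)C(N)=O` gives 5700 nM in this assay. Among the compounds with values here, the one measured step, a 7.3-fold lower number from compound 1 to compound 2 (0.86 log units; beyond the scatter), put isopropyl in place of hydroxy at this carbon. Compound 3 `CSCC[C@H](NC(=O)[C@H](CC(C)C)NC(=O)[C@H](CC(N)=O)NC(=O)CC[C@H](NS(=O)(=O)c1ccc(Cl)c(C(F)(F)F)c1)C(=O)O)C(N)=O` now takes the isopropyl away again: carbamoyl in place of isopropyl on a saturated chain carbon, two bonds along the chain from an amide-type nitrogen and a carbonyl carbon. Within the data shown here, with only that step to go on, a move back toward the number of compound 1 is expected, roughly the size of a 5.1-fold higher number from compound 2 to compound 3 (0.71 log units; beyond the scatter) in the weaker direction. Compound 3 is therefore estimated at 4000 nM in this assay, within 1500 nM to 11000 nM.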

Compound 3, half-maximal inhibitory concentration: 7500 nM
Beside the measured number, compound 3's estimate is 1.9-fold (0.27 log units) below it; the range from low to high includes it.
By their numbers in this assay, from the lowest: compound 2; then compounds 1 and 3 (each within the scatter of the next).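

Carbamoyl in place of isopropyl gives a 9.6-fold higher number from compound 2 to compound 3 (0.98 log units; beyond the scatter), so the second polar-free comparison at this carbon runs the same way as the first: among the three compounds, only compound 2 stands apart. Carbamoyl in place of hydroxy gives a 1.3-fold higher number from compound 1 to compound 3 (0.12 log units; within the scatter), which leaves these two groups unresolved at this position. Nothing at hand gives a reason for either step.

Still open, from the compounds shown here alone, is whether a longer chain such as n-butyl matches or improves on isopropyl here. A carboxylic acid or an amine at this carbon also remains to be placed against compound 1 and compound 3.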